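Hydrogen in place of ethyl on the shared core

This account rests on a few compounds, and the source may have more. Where it says the series, first, only, none or still open, it means among the compounds named here.

Measured so far in a functional assay on aorta (Rattus norvegicus, strain Wistar), in the presence of a further agent that is not named here; on this read-out lower numbers stand for stronger inhibition and higher numbers for weaker inhibition:
- compound 1 `Cc1ccc2c(c1)N(C1=CCCC1=O)CC(C)(C)S2` gives 19500 nM
- compound 2 `CCc1ccc2c(c1)N(C1=CCCC1=O)CC(C)(C)S2` gives 6460 nM

Among the compounds with values here, compound 2 holds the lower of the two numbers, and compound 1 is its only measured neighbour. Compound 3 `CC1(C)CN(C2=CCCC2=O)c2ccccc2S1` has not yet been measured. Its difference from compound 2 is hydrogen in place of ethyl on an aromatic carbon.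

Within the data shown here, one measured step bears on this change: a 3.0-fold lower number from compound 1 to compound 2 (0.48 log units; beyond the scatter), with methyl in place of hydrogen on a saturated chain carbon bound to an aromatic carbon. That step is modest but beyond the scatter, and it runs from methyl to ethyl at the same place. Compound 3 goes the opposite way and removes the whole ethyl group, so a higher number is expected in this assay, of modest size or somewhat more. Among the measured compounds shown here, a single step is a thin basis, and no measured compound yet carries hydrogen there. The expected change is a 4.6-fold higher number from compound 2 to compound 3 (0.67 log units; beyond the scatter) as a rise. The estimate for compound 3 is 30000 nM within an expected range (11000 nM to 80000 nM).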

Compound 3, half-maximal inhibitory concentration: 20900 nM
The estimate for compound 3 lay 1.4-fold (0.16 log units) above the measured number; the range from low to high includes it.
By their numbers in this assay, from the lowest: compound 2; then compounds 1 and 3 (each within the scatter of the next).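

In this assay, removing ethyl now has a step of its own (a reading of a 3.2-fold higher number from compound 2 to compound 3 (0.51 log units; beyond the scatter)), so hydrogen in place of ethyl on this aromatic carbon no longer rests on the methyl-to-ethyl step alone. The second new step (a reading of a 1.1-fold higher number from compound 1 to compound 3 (0.03 log units; within the scatter)) lies within the scatter, so hydrogen and methyl on this carbon cannot be told apart here, and of the three groups only ethyl stands apart, with compound 2 beyond the scatter of both compound 1 and compound 3. Nothing on hand explains why ethyl separates from methyl and hydrogen at this place.

The compounds shown leave open whether a longer chain such as propyl would take the number lower than in compound 2 or whether the gain ends at ethyl. They also leave open how a group of another kind on this aromatic carbon, such as methoxy or an amine, would compare, and whether the ethyl step would be the same size with any other part of the shared core changed.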